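Oxazolidinedione in place of succinimide on a diaryl ether scaffold

The compounds below may be only part of what the source reports. "The series", "measured", "known", "first", "only" and "open" are said of these compounds alone.

Compound 1 `Cc1ccc(C)c(Oc2ccc(CC3SC(=O)NC3=O)cc2)c1`: 238 nM
Compound 2 `Cc1cccc(Oc2ccc(CC3SC(=O)NC3=O)cc2)c1`: 203 nM
Compound 3 `O=C1CC(Cc2ccc(Oc3ccc(Cl)cc3Cl)cc2)C(=O)N1`: 6450 nM

In a functional assay for agonist activity at Free fatty acid receptor 1 (Homo sapiens), read by FLIPR, in the presence of a further agent that is not named here (on this read-out lower numbers stand for an effect already at smaller amounts and higher numbers for an effect only at larger amounts of compound), compound 3 gives the highest number of the three, beyond the scatter from both compound 1 and compound 2, which lie within the scatter of each other after a 1.2-fold lower number from compound 1 to compound 2 (0.07 log units; within the scatter). Compound 4 `O=C1NC(=O)C(Cc2ccc(Oc3ccc(Cl)cc3Cl)cc2)O1` differs from compound 3 in the ring on the chain: 2,4-dioxo-1,3-oxazolidin-5-yl in place of 2,5-dioxopyrrolidin-3-yl on a saturated chain carbon bound to an aromatic carbon. Within the data shown here, no measured step touches this ring, so the only guide is the shared diaryl ether and compound 3 itself. The author expects a modest decrease, a 1.8-fold lower number from compound 3 to compound 4 (0.27 log units; within the scatter), with the direction uncertain. Compound 4 is therefore estimated at 3500 nM, between 900 nM and 14000 nM.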

Compound 4, half-maximal effective concentration: 4020 nM
Beside the measured number, compound 4's estimate is 1.1-fold (0.06 log units) below it, and the stated range covers the measured number.
By their numbers in this assay, from the lowest: compounds 2 and 1 (each within the scatter of the next); then compounds 4 and 3 (each within the scatter of the next).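

On the saturated chain carbon bound to an aromatic carbon, 2,4-dioxo-1,3-oxazolidin-5-yl can replace 2,5-dioxopyrrolidin-3-yl with no difference that stands clear of the scatter in this assay, with a 1.6-fold lower number from compound 3 to compound 4 (0.21 log units; within the scatter). Among these compounds, this is the first view of this ring position, and here the added ring hetero atom and hydrogen-bond acceptor come with no change beyond the scatter. No available measurement bears on this result. Open, as far as these compounds go, is whether a carboxylic acid in place of either ring would give a similar number, and how a longer chain would fare.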